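The source may report more compounds than this note shows. Statements on the series, on what has been measured and on what is new or still open speak of the compounds shown alone.

In an ADME assay on microsomes from liver (Homo sapiens) for metabolic stability (a lower number here means slower removal, a higher number faster removal of the compound), three compounds sharing one core have been measured. Compound 1 `Cc1ccc([C@H](C)NC(=O)Cn2nnc3ccccc3c2=O)cc1` carries hydrogen at the aromatic carbon that varies. Compound 1 gives < 9.9 mL/min/kg, which is a limit of the assay and not a number. With methoxy at that carbon, compound 2 `COc1ccc2nnn(CC(=O)N[C@@H](C)c3ccc(C)cc3)c(=O)c2c1` gives 58 mL/min/kg. With trifluoromethyl there, compound 3 `Cc1ccc([C@H](C)NC(=O)Cn2nnc3ccc(C(F)(F)F)cc3c2=O)cc1` gives 435 mL/min/kg, the highest number measured. Its closest comparison is a 7.5-fold higher number from compound 2 to compound 3 (0.88 log units; beyond the scatter).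

Compound 4 `Cc1ccc([C@H](C)NC(=O)Cn2nnc3ccc(F)cc3c2=O)cc1` differs from compound 3 in one place: fluoro in place of trifluoromethyl on an aromatic carbon. Going by the values given here, no fluoro compound has been measured, so the guides are an at least 43-fold higher number from compound 1 to compound 3 (1.64 log units; beyond the scatter) and an at least 5.8-fold higher number from compound 1 to compound 2 (0.76 log units; beyond the scatter). Both steps rest on (the limit of < 9.9 mL/min/kg in this assay, at which 1 of the 3 values shown sits), so their true sizes are not known. Only a small group enters at this carbon, and compound 4 is therefore expected to lie much nearer to compound 1 than to compound 3, given an at least 43-fold higher number from compound 1 to compound 3 (1.64 log units; beyond the scatter). A large step to a lower number is expected, namely a 22-fold lower number from compound 3 to compound 4 (1.34 log units; beyond the scatter). For compound 4 the estimated clearance is 20 mL/min/kg, with an expected range of 9 mL/min/kg to 80 mL/min/kg.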

Compound 4, clearance in the Homo sapiens assay: 182 mL/min/kg
Compound 4: the middle estimate sits 9.1-fold (0.96 log units) below what was measured; measured number above the stated range.
By their numbers in the Homo sapiens assay, from the lowest: compound 2; then compound 4; then compound 3. At a limit, below all of these: compound 1.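

Even fluoro, the smallest group to enter at this carbon, moves the number well away from hydrogen in the Homo sapiens assay, where compound 4 gives 182 mL/min/kg: an at least 18-fold higher number from compound 1 to compound 4 (1.26 log units; beyond the scatter). Compound 4 also falls between the two substituted compounds, with a 3.1-fold higher number from compound 2 to compound 4 (0.50 log units; beyond the scatter) and a 2.4-fold lower number from compound 3 to compound 4 (0.38 log units; beyond the scatter), so compound 2 goes against any reading in which the number simply rises with the size of the group. In a physicochemical assay for solubility, read by HPLC, in phosphate buffer, with a stated time of 16 h, at pH 6.8 (on this read-out lower numbers stand for lower solubility and higher numbers for higher solubility), compound 3 gives 6600 nM and compound 4 gives 3400 nM; the same exchange gives a 1.9-fold lower number from compound 3 to compound 4 (0.29 log units; within the scatter), which shows no difference beyond the scatter.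

As far as these compounds go, compound 1 gives < 9.9 mL/min/kg, which is a limit and not a number, so the true size of each step from it stays open: the limit of < 9.9 mL/min/kg in the Homo sapiens assay, at which 1 of the 4 values shown sits. From the compounds shown here alone, whether a nitrile or an amine at this carbon would bring the clearance back towards that of compound 1 also remains open.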